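This account rests on a few compounds, and the source may have more. Where it says the series, first, only, none or still open, it means among the compounds named here.

Of the compounds shown here, two that share one core have been tested in a functional assay on SK-OV-3 cells (Homo sapiens) for inhibition, read by sulforhodamine B assay, with a stated time of 48 h; on this read-out higher numbers stand for lower toxicity in this test and lower numbers for higher toxicity in this test. Compound 1 `O=C(Nc1cccc(-n2cc(-c3ccncc3)c(-c3ccc(Cl)c(O)c3)n2)c1)Nc1cccc(C(F)(F)F)c1` carries a 4-chloro-3-hydroxyphenyl group and a trifluoromethyl-bearing urea partner; in this assay compound 1 returns only a limit, > 32500 nM. Compound 2 `COc1cc(-c2nn(-c3cccc(NC(=O)Nc4ccc(Cl)c(Cl)c4)c3)cc2-c2ccncc2)ccc1Cl` pairs a 4-chloro-3-methoxyphenyl group with a dichlorophenyl urea partner; in this assay compound 2 likewise gives only a limit, > 50000 nM. Compound 2 thus stands at the edge of what the measurement can report (the limit of > 50000 nM in this assay, at which 1 of the 2 values shown sits). Compound 1 sits at a limit as well (the limit of > 32500 nM in this assay, at which 1 of the 2 values shown sits), so neither compound yields a number to set against the other. Compound 3 `O=C(Nc1cccc(-n2cc(-c3ccncc3)c(-c3ccc(Cl)c(O)c3)n2)c1)Nc1ccc(Cl)c(Cl)c1` differs from compound 2 by hydrogen in place of methyl on an oxygen on an aromatic ring. With both neighbours at a limit, the expected step is none beyond the scatter in either direction a number no higher from compound 2 to compound 3 (the limit leaves the size open). Compound 3 is therefore expected to come in at 50000 nM, within 15000 nM to 150000 nM, most likely reported as a limit rather than a number.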

Compound 3, concentration lethal to 50% of the cells: > 32500 nM
Compound 3: no number, only a limit; the forecaster's own chance of this, stated with the estimate: 75%; the middle value is on the limit's open side.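

Compound 3 returns only a limit in this assay, as do compound 1 and compound 2, so neither step to compound 3 can be read. The compounds shown leave open whether methoxy to hydroxy, or 3-(trifluoromethyl)phenyl to 3,4-dichlorophenyl, changes the lethal concentration at all.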